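Compound 1 and the 3,4-dichlorophenyl swap

The compounds below may be only part of what the source reports. "The series", "measured", "known", "first", "only" and "open" are said of these compounds alone.

Going by the values given here, in a functional assay on NCI-H322M cells (Homo sapiens) for inhibition, read by sulforhodamine B assay, with a stated time of 48 h (on this read-out higher numbers stand for weaker inhibition of growth and lower numbers for stronger inhibition of growth), compound 1 (`O=C(Nc1cccc(-n2cc(-c3ccncc3)c(-c3ccc(Cl)c(O)c3)n2)c1)Nc1cccc(C(F)(F)F)c1`) gives 6410 nM, the highest of the three numbers so far and beyond the scatter from both others. Compound 2 (`COc1cc(-c2nn(-c3cccc(NC(=O)Nc4cc(C(F)(F)F)cc(C(F)(F)F)c4)c3)cc2-c2ccncc2)ccc1Cl`) gives 1020 nM and compound 3 (`COc1cc(-c2nn(-c3cccc(NC(=O)Nc4ccc(Cl)c(Cl)c4)c3)cc2-c2ccncc2)ccc1Cl`) gives 1690 nM, two values within the scatter of each other.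

Compound 4 (`O=C(Nc1cccc(-n2cc(-c3ccncc3)c(-c3ccc(Cl)c(O)c3)n2)c1)Nc1ccc(Cl)c(Cl)c1`) is compound 1 with 3,4-dichlorophenyl in place of 3-(trifluoromethyl)phenyl on an amide-type nitrogen. Among the compounds with values here, no measured pair shows this change alone, so its size has to be inferred. Compound 3 carries the same 3,4-dichlorophenyl and gives 1690 nM, but it also differs from compound 1 elsewhere, so only part of that gap is expected to carry over. A modest move toward stronger inhibition of growth is expected in this assay, and the estimate is a 2.1-fold lower number from compound 1 to compound 4 (0.33 log units; beyond the scatter). For compound 4 the expected value is 3000 nM, with an estimated range of 1300 nM to 6500 nM.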

Compound 4, concentration for 50% growth inhibition: 2890 nM
Beside the measured number, compound 4's estimate is 1.0-fold (0.02 log units) above it; the range from low to high includes it.
By their numbers in this assay, from the lowest: compounds 2, 3 and 4 (each within the scatter of the next, the first and the last beyond it); then compound 1.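

On an amide-type nitrogen, 3,4-dichlorophenyl in place of 3-(trifluoromethyl)phenyl can now be read alone: in this assay the swap gives a 2.2-fold lower number from compound 1 to compound 4 (0.35 log units; beyond the scatter) as a modest step. With 3,4-dichlorophenyl held fixed, hydrogen in place of methyl on an oxygen on an aromatic ring gives a 1.7-fold higher number from compound 3 to compound 4 (0.23 log units; within the scatter), so this position shows no readable effect of that change in this pair. Nothing available on either compound accounts for these steps.

Open questions remain at both positions: how a morpholine or a carboxylic acid would read in place of 3,4-dichlorophenyl on the amide-type nitrogen, and how an ethyl or longer chain would read in place of methyl on that oxygen. From the compounds shown here alone, whether the step seen with hydrogen on that oxygen carries over to the methyl-bearing compounds also remains open.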